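This account rests on a few compounds, and the source may have more. Where it says the series, first, only, none or still open, it means among the compounds named here.

In an assay on HEK293 cells for positive allosteric modulation of metabotropic glutamate receptor 5 (Homo sapiens), read by FLIPR (a lower number here means that less compound is needed, a higher number that more compound is needed for the effect), compound 3 `Cc1cccc(-c2noc(C3CN(C(=O)c4cccc(F)c4)C3)n2)c1` gives only a limit, > 10000 nM. Its companion compound 2 `Cc1cccc(-c2noc(C3CN(C(=O)c4ccccc4F)C3)n2)c1` likewise sits at a limit, > 10000 nM. Among the measured compounds shown here, the one measured step, a step that the two limits leave unreadable from compound 2 to compound 3, is therefore unreadable in size, as the limit of > 10000 nM in this assay, at which 2 of the 3 values shown sit, explains. The step that the account now follows, (4,4-difluorocyclohexyl in place of 3-fluorophenyl on a carbonyl carbon), yields compound 4 `Cc1cccc(-c2noc(C3CN(C(=O)C4CCC(F)(F)CC4)C3)n2)c1`. For the measured compounds named here, no measured step among the three compounds covers this exchange of the amide substituent, so its size cannot be read from any pair. What the numbers do show is that compound 1 `O=C(C1CCC(F)(F)CC1)N1CC(c2nc(-c3cccc(Cl)c3)no2)C1`, which carries the same 4,4-difluorocyclohexyl group on its carbonyl carbon, gives 180 nM in this assay, while differing from compound 4 elsewhere. Compound 4 is therefore expected to leave the limit behind and come in near 300 nM, with a range from 80 nM to 2000 nM. The estimated step of an at least 33-fold lower number from compound 3 to compound 4 (1.52 log units; beyond the scatter) can only be stated as a movement off the limit, not as a measured size.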

Compound 4, half-maximal effective concentration: 590 nM
Compound 4: the middle estimate sits 2.0-fold (0.29 log units) below what was measured, and the stated range covers the measured number.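

In this assay, 4,4-difluorocyclohexyl on the carbonyl carbon brings this series off its limit, with an at least 16-fold lower number from compound 3 to compound 4 (1.22 log units; beyond the scatter) and an at least 16-fold lower number from compound 2 to compound 4 (1.22 log units; beyond the scatter). These two sizes are minimum sizes only, and the step between the two fluorophenyl compounds cannot be read: the limit of > 10000 nM in this assay, at which 2 of the 4 values shown sit. Among the compounds shown here, with 4,4-difluorocyclohexyl held in place, the aromatic substituent can also be read for the first time, and methyl in place of chloro on an aromatic carbon gives a 3.3-fold higher number from compound 1 to compound 4 (0.52 log units; beyond the scatter), a modest step.

As far as these compounds go, whether the change at the carbonyl carbon follows the two fluorine atoms or the non-aromatic ring stays open, and a plain cyclohexyl group there would separate the two. Also open, from the compounds shown here alone, is how an amine or a carboxylic acid on that ring would read, and whether chloro in place of methyl would lift a fluorophenyl amide off the limit.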